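A few compounds are considered here, and "the series" means these few. Any claim that something is new, unique, unknown or untested is made for them only; others in the source may bear on it.

Working notes on the arylthio-pyridine acid series.

Three compounds have numbers in an assay on HEK293 cells for inhibition of solute carrier family 22 member 12 (Homo sapiens), read by scintillation counting, with stated times of 30 min and 15 min; a lower number here means a stronger inhibitor, a higher number a weaker inhibitor. Compound 1 `N#Cc1ccc(Oc2cnccc2SCCCCC(=O)O)c2ccccc12` gives 4220 nM. Compound 2 `N#Cc1ccc(Nc2cnccc2SCCCC(=O)O)c2ccccc12` gives 2780 nM. Compound 3 `CN(c1cnccc1SCCCCC(=O)O)c1ccc(C#N)c2ccccc12` gives 3580 nM. Compound 2 returns the lowest of the three numbers, but its gap to compound 3 and its gap to compound 1 both lie within the scatter, so no ranking among the three is claimed; the set reads as one cluster.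

The next compound, compound 4 `N#Cc1ccc(Nc2cnccc2SCCCCCCC(=O)O)c2ccccc12`, is compound 2 with a longer acid chain: 3-carboxypropyl in place of carboxy on a saturated chain carbon, three bonds along the chain from a sulfur. Within the data shown here, no pair of measured compounds differs in this one place alone, so the size of this step has not been seen directly. Compound 1 and compound 3 each carry a chain one carbon longer than compound 2 and both sit in the same cluster, which suggests chain length in this range moves the number little, though neither of them differs from compound 2 in only that place. The expectation for the step from compound 2 to compound 4 is therefore no change beyond the scatter, or at most a modest weakening, a 1.4-fold higher number from compound 2 to compound 4 (0.16 log units; within the scatter). Compound 4 is estimated at 4000 nM, with a range from 1500 nM to 11000 nM.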

Compound 4, half-maximal inhibitory concentration: 5750 nM
Estimate against measurement, compound 4: 1.4-fold (0.16 log units) below, and the stated range covers the measured number.
By their numbers in this assay, from the lowest: compounds 2, 3, 1 and 4 (each within the scatter of the next, the first and the last beyond it).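

Among these compounds, putting 3-carboxypropyl in place of carboxy on a saturated chain carbon, three bonds along the chain from a sulfur, gives a 2.1-fold higher number from compound 2 to compound 4 (0.32 log units; beyond the scatter) in this assay, the one step that isolates this place. Among the compounds shown here, the direction at this position is thus seen directly for the first time: with the core unchanged and the terminal acid kept, adding carbons to the chain raises the number, though the step is modest and this pair alone does not define a trend with chain length. No measurement in hand bears on the origin of this step.

Carboxymethyl at this place would fall between the two chain lengths read here, and 6-carboxyhexyl would extend the chain further, so the shape of the relation between chain length and the number, whether gradual, abrupt or reversing, remains open. Also open, on these data alone, are whether the same chain change gives a similar step on the cores of compound 1 and compound 3, and how a primary amide in place of the terminal carboxylic acid would read at this position.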